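The source may hold more compounds than are shown below. What is called first, only, known or untested is meant among the compounds shown, and "the series" means these compounds.

Working notes on the series, read in a functional assay on A549 cells (Homo sapiens) for antiproliferative activity, read by sulforhodamine B assay, with a stated time of 48 h; a lower number here means a stronger inhibitor, a higher number a weaker inhibitor. Three compounds on a shared core are measured: compound 1 (`COc1cccc(/C=C/C(=O)C(=Cc2ccc(F)cc2)C(=O)/C=C/c2cccc(OC)c2OC)c1OC`) gives 340 nM, compound 2 (`COc1cc(OC)c(C=C(C(=O)/C=C/c2cccc(OC)c2OC)C(=O)/C=C/c2cccc(OC)c2OC)c(OC)c1`) gives 630 nM, and compound 3 (`COc1cc(C=C(C(=O)/C=C/c2cccc(OC)c2OC)C(=O)/C=C/c2cccc(OC)c2OC)cc(Br)c1O`) gives 200 nM. Compound 3 stands at the low end of these numbers, though not apart from compound 1, since a 1.7-fold lower number from compound 1 to compound 3 (0.23 log units; within the scatter) stays within the scatter. Only the comparison with compound 2 clears the scatter, at a 3.2-fold lower number from compound 2 to compound 3 (0.50 log units; beyond the scatter).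

The next member, compound 4 (`COc1ccc(C=C(C(=O)/C=C/c2cccc(OC)c2OC)C(=O)/C=C/c2cccc(OC)c2OC)cc1O`), has not been measured. Its change is 3-hydroxy-4-methoxyphenyl in place of 3-bromo-4-hydroxy-5-methoxyphenyl on a double-bonded chain carbon bound to a double-bonded chain carbon.

For the measured compounds named here, no measured pair isolates the loss of the bromine, so the evidence is indirect. All three measured steps exchange the group at this same place, and they stay small: a 1.9-fold higher number from compound 1 to compound 2 (0.27 log units; within the scatter) lies within the scatter, and the largest, a 3.2-fold lower number from compound 2 to compound 3 (0.50 log units; beyond the scatter), is only modest. On that basis, no step beyond the scatter is expected in this assay, with a slight lean towards a higher number, as compound 3 at 200 nM sits at the low end of the series.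

The expected change is a 1.6-fold higher number from compound 3 to compound 4 (0.20 log units; within the scatter). For compound 4 the estimated value is 320 nM, with an expected range of 130 nM to 800 nM.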

Compound 4, half-maximal inhibitory concentration: 270 nM
Beside the measured number, compound 4's estimate is 1.2-fold (0.07 log units) above it; the measured number falls inside the stated range.
By their numbers in this assay, from the lowest: compounds 3, 4, 1 and 2 (each within the scatter of the next, the first and the last beyond it).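

In this assay, the group on a double-bonded chain carbon bound to a double-bonded chain carbon can change from 3-bromo-4-hydroxy-5-methoxyphenyl to the bromine-free 3-hydroxy-4-methoxyphenyl without a step that clears the scatter: a 1.4-fold higher number from compound 3 to compound 4 (0.13 log units; within the scatter). The new group also stays within the scatter of 4-fluorophenyl, a 1.3-fold lower number from compound 1 to compound 4 (0.10 log units; within the scatter), but clears it against 2,4,6-trimethoxyphenyl, a 2.3-fold lower number from compound 2 to compound 4 (0.37 log units; beyond the scatter), so two groups now stand apart from 2,4,6-trimethoxyphenyl, while 4-fluorophenyl goes against any wider pattern by staying within the scatter of all three other groups. No other measurement bears on these steps.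

The hydroxy and methoxy numbering changes along with the loss of the bromine in this step, so the contribution of the bromine alone remains unresolved. All four groups shown are substituted phenyl rings, which leaves open how an amine, a carboxylic acid or a longer chain such as butoxy would read at this place.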